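The source may hold more compounds than are shown below. What is called first, only, known or untested is meant among the compounds shown, and "the series" means these compounds.

Measured compounds:
compound 1 `COc1ccc(C(=O)NCc2ccc(CNS(=O)(=O)c3ccc(C)cc3)cc2)cc1` gives 100 nM in an assay on MDA-MB-231 cells for binding affinity to C-X-C chemokine receptor type 4 (Homo sapiens), read by immunofluorescence and microscopy, with stated times of 10 min and 30 min; a higher number here means that more compound is needed for the effect, a lower number that less compound is needed;
compound 2 `Cc1ccccc1C(=O)NCc1ccc(CNS(=O)(=O)c2ccccc2)cc1` gives 1 nM;
compound 3 `Cc1ccc(S(=O)(=O)NCc2ccc(CNC(=O)c3ccccc3C)cc2)cc1` gives 100 nM.

Among these three, compound 2 stands lowest, its nearest neighbour being compound 1 at a separation beyond the scatter. Compound 4 `O=C(NCc1ccc(CNS(=O)(=O)c2ccccc2)cc1)c1ccc(Cl)cc1` is not yet measured; the change from compound 2 is 4-chlorophenyl in place of 2-methylphenyl on a carbonyl carbon. Among the measured compounds shown here, two measured steps bear on it. The step of no change at the digits printed from compound 1 to compound 3 (within the scatter) shows that exchanging the aryl on the carbonyl carbon left the number essentially unchanged, whereas the step of a 100-fold higher number from compound 2 to compound 3 (2.00 log units; beyond the scatter) shows the large effect came from a change elsewhere. On this basis only a small step, within the scatter, is expected: a 2.0-fold higher number from compound 2 to compound 4 (0.30 log units; within the scatter). Compound 4 is therefore estimated at 2 nM, with a range from 0.3 nM to 20 nM.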

Compound 4, effective concentration (reported as EC, without a stated level of effect): 100 nM
Compound 4: middle estimate off by 50-fold (1.70 log units), on the low side, and the stated range ends below it.
By their numbers in this assay, from the lowest: compound 2; then compounds 1, 3 and 4 (each within the scatter of the next).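

On the core of compound 2, the aryl on the carbonyl carbon proves decisive in this assay: 4-chlorophenyl in place of 2-methylphenyl gives a 100-fold higher number from compound 2 to compound 4 (2.00 log units; beyond the scatter). The earlier exchange on this carbonyl carbon, no change at the digits printed from compound 1 to compound 3 (within the scatter), had shown no such sensitivity, so the outcome of a change here differs between these two pairs.

Nothing available explains this difference. As far as these compounds go, it remains open whether the number follows the loss of 2-methylphenyl or the entry of 4-chlorophenyl, and how a plain phenyl, 2-chlorophenyl or an aminophenyl would read here.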